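Solubility notes on the amide series, toward compound 4

The source may report more compounds than this note shows. Statements on the series, on what has been measured and on what is new or still open speak of the compounds shown alone.

Compound 3 `COc1ccc2[nH]c(C(=O)N3CC(=O)N(Cc4ccccc4)[C@@H](CN4C(=O)c5ccccc5C4=O)C3)cc2c1` stands at a limit in a physicochemical assay for solubility, read by spectrophotometry, in phosphate buffer, with a stated time of 2 h, at pH 7.4; on this read-out higher numbers stand for higher solubility and lower numbers for lower solubility: compound 3 gives > 100000 nM, which is a limit of the assay and not a number. Among the measured compounds shown here, compound 1 `COc1ccc2[nH]c(C(=O)N3CC(=O)N(Cc4ccccc4)[C@@H](CN4CCC(C)CC4)C3)cc2c1` is the only member of the set with a read number; in this assay compound 1 gives 93100 nM. Compound 2 `COc1ccc2[nH]c(C(=O)N3CC(=O)N(Cc4ccccc4)[C@@H](CN4CCC(OC)CC4)C3)cc2c1` also sits at a limit; in this assay compound 2 gives > 25000 nM. With two of three values at limits, the steps are thin: an at least 1.0-fold higher number from compound 1 to compound 3 (0.03 log units; that floor lies within the scatter), while a step that the limit leaves unreadable from compound 1 to compound 2 and a step that the two limits leave unreadable from compound 2 to compound 3. The first is capped by the limit of > 100000 nM in this assay, at which 1 of the 3 values shown sits, and the others by the limit of > 25000 nM in this assay, at which 1 of the 3 values shown sits, so none carries a direction.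

Compound 4 `COc1ccc2[nH]c(C(=O)N3CC(=O)N(Cc4ccccc4)[C@@H](CN4CCCc5ccccc54)C3)cc2c1` differs from compound 3 in one place: a group of 10 heavy atoms (9 carbon, 1 nitrogen; one six-membered non-aromatic ring with 1 hetero atom, one six-membered aromatic ring of carbon only) in place of a group of 11 heavy atoms (8 carbon, 1 nitrogen, 2 oxygen; one five-membered non-aromatic ring with 1 hetero atom, one six-membered aromatic ring of carbon only), on a saturated chain carbon bound to a saturated ring carbon. For the measured compounds named here, no measured step exchanges this group for anything of the kind, so the only guidance is that every member of the set so far lies at or above the same broad region of solubility in this assay. Compound 4 is therefore expected to sit in that region too, and is estimated at 60000 nM, with a range from 15000 nM to 150000 nM. The step this implies, an at least 1.6-fold lower number from compound 3 to compound 4 (0.22 log units; that floor lies within the scatter), is expected to be unreadable against the limit of compound 3.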

Compound 4, solubility: 8500 nM
Compound 4: middle estimate off by 7.1-fold (0.85 log units), on the high side, outside the stated range (below it).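

In this assay, among the compounds shown here, the group on the saturated chain carbon bound to a saturated ring carbon now has a readable effect: exchanging 4-methylpiperidin-1-yl for 1,2,3,4-tetrahydroquinolin-1-yl gives an 11-fold lower number from compound 1 to compound 4 (1.04 log units; beyond the scatter), the only step in the set between two read numbers. The other two exchanges also lie beyond the scatter, with an at least 11-fold lower number from compound 3 to compound 4 (1.07 log units; beyond the scatter) and an at least 2.9-fold lower number from compound 2 to compound 4 (0.46 log units; beyond the scatter), though both are floors set by limits of the assay and not full sizes. Compound 3 also carries a six-membered aromatic ring of carbon only, yet an at least 11-fold lower number from compound 3 to compound 4 (1.07 log units; beyond the scatter) separates it from compound 4, so the presence of such a ring does not by itself go with the lower number in this set.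

On these data alone, the steps from compound 1 to compound 2 and from compound 2 to compound 3 cannot be read, so the order among those three stays open. Also open, as far as these compounds go, is where a morpholin-4-yl group, a piperidine bearing a carboxylic acid or an open-chain diethylamino group would fall at this place in this assay.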